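This account rests on a few compounds, and the source may have more. Where it says the series, first, only, none or still open, it means among the compounds named here.

Measured in a functional assay on SH-SY5Y cells (Homo sapiens) for antiproliferative activity, read by MTT assay, with a stated time of 48 h; a higher number here means a weaker inhibitor of growth, a lower number a stronger inhibitor of growth:
- compound 1 `COc1ccc(N(C)c2ncnc3[nH]cnc23)cc1`: > 100000 nM (a limit of the assay)
- compound 2 `COc1ccc(N(C)c2ncnc3c2ncn3C)cc1`: > 100000 nM (a limit of the assay)

Compound 2 has no numerical value in this assay; its > 100000 nM is a limit and not a number. Going by the values given here, the same holds across the series so far, which shows (the limit of > 100000 nM in this assay, at which 2 of the 2 values shown sit).

Compound 3 `COc1ccc(Cn2cnc3c(N(C)c4ccc(OC)cc4)ncnc32)cc1` differs from compound 2 as follows: 4-methoxyphenyl in place of hydrogen on a saturated chain carbon bound to an aromatic nitrogen. In words, this is 4-methoxyphenyl in place of hydrogen on a saturated chain carbon bound to an aromatic nitrogen, or methyl to 4-methoxybenzyl when cut one bond further out.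

Among the compounds with values here, the only measured step that bears on this change is a step that the two limits leave unreadable from compound 1 to compound 2. It offers no size to carry over. Within the data shown here, the expectation therefore rests on the limit of compound 2, > 100000 nM, and has no measured step behind it.

The expected at least 5.0-fold lower number from compound 2 to compound 3 (0.69 log units; beyond the scatter) points toward stronger growth inhibition, though with low confidence, and a second reading at the limit remains quite possible.

For compound 3 the estimate is 20000 nM, with an expected range of 2000 nM to 100000 nM.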

Compound 3, concentration for 50% growth inhibition: 27000 nM
Compound 3: the middle estimate sits 1.4-fold (0.13 log units) below what was measured, and the stated range covers the measured number.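

In this assay, going by these compounds alone, 4-methoxybenzyl on the aromatic nitrogen gives the first readable change, with an at least 3.7-fold lower number from compound 2 to compound 3 (0.56 log units; beyond the scatter) when it replaces methyl. Set against the hydrogen on that nitrogen, the same group gives an at least 3.7-fold lower number from compound 1 to compound 3 (0.56 log units; beyond the scatter), so this change registers from either starting point, although both sizes are bounds rather than exact values. The step from hydrogen to methyl on that nitrogen cannot be read, and among the compounds shown, a numerical value appears only with 4-methoxybenzyl, while the others remain at a limit: the limit of > 100000 nM in this assay, at which 2 of the 3 values shown sit.

From the compounds shown here alone, it remains open whether the methoxy group on the ring matters, since a plain benzyl group would separate its contribution from that of the ring and its chain carbon. Also open, going by these compounds, is whether the reading holds or changes with a longer chain such as 2-phenylethyl, or with an amine or a carboxylic acid in place of the methoxy group.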